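Six-membered ring swapped for imidazolyl on the benzamide arm

This account rests on a few compounds, and the source may have more. Where it says the series, first, only, none or still open, it means among the compounds named here.

Measured so far in an assay on isolated protein for inhibition of serine protease 1 (Homo sapiens); on this read-out lower numbers stand for stronger inhibition and higher numbers for weaker inhibition:
compound 1 `COC(=O)[C@H](Cc1cccc(C(=N)N)c1)[C@@H](C)NC(=O)c1ccc(-c2ccccn2)cc1` gives 51 nM
compound 2 `COC(=O)[C@H](Cc1cccc(C(=N)N)c1)[C@@H](C)NC(=O)c1ccc(-c2cccc[n+]2C)cc1` gives 36 nM
compound 3 `COC(=O)[C@H](Cc1cccc(C(=N)N)c1)[C@@H](C)NC(=O)c1ccc(-c2ccc[n+](C)c2)cc1` gives 52 nM

Compound 3 has the highest of the three numbers, but its gaps to the others are small: a 1.0-fold higher number from compound 1 to compound 3 (0.01 log units; within the scatter) and a 1.4-fold higher number from compound 2 to compound 3 (0.16 log units; within the scatter) both sit within the scatter, as does a 1.4-fold lower number from compound 1 to compound 2 (0.15 log units; within the scatter). Across the three, exchanging one six-membered ring with a single hetero atom for another at the same aromatic carbon has not moved this assay beyond its noise.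

Compound 4 `COC(=O)[C@H](Cc1cccc(C(=N)N)c1)[C@@H](C)NC(=O)c1ccc(-n2ccnc2)cc1` differs from compound 3 by a group of 5 heavy atoms (3 carbon, 2 nitrogen; one five-membered aromatic ring with 2 hetero atoms) in place of a group of 7 heavy atoms (6 carbon, 1 nitrogen; one six-membered aromatic ring with 1 hetero atom), on an aromatic carbon. Among the measured compounds shown here, none of the measured steps covers this particular exchange; the closest precedent is the trio of ring swaps at the same place, each of which stayed within the scatter. For the measured compounds named here, the entering group is smaller and carries no charge, and the series gives no step that shows what such a change does here. The working assumption is therefore a step of modest size in either direction, most likely none beyond the scatter.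

Compound 4 is expected to give about 55 nM in this assay, within a range of 20 nM to 160 nM, which corresponds to an expected step of a 1.1-fold higher number from compound 3 to compound 4 (0.02 log units; within the scatter).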

Compound 4, inhibition constant: > 2900 nM
Compound 4 ended at the assay's limit; the forecaster's own chance of this, stated with the estimate: 3%; at least 52-fold (1.72 log units) between middle value and limit.
By their numbers in this assay, from the lowest: compounds 2, 1 and 3 (each within the scatter of the next). At a limit, above all of these: compound 4.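

Compound 4 stands at a limit of this assay and not at a number: the limit of > 2900 nM in this assay, at which 1 of the 4 values shown sits. Among the compounds shown here, the earlier ring swaps on this aromatic carbon all stayed within the scatter, which made the position look indifferent to the group it carries, but 1H-imidazol-1-yl is the first group here to go beyond the scatter, with an at least 55-fold higher number from compound 3 to compound 4 (1.74 log units; beyond the scatter) and an at least 80-fold higher number from compound 2 to compound 4 (1.90 log units; beyond the scatter). The step from the pyridin-2-yl group, which like 1H-imidazol-1-yl has no net charge, is also large, at an at least 56-fold higher number from compound 1 to compound 4 (1.75 log units; beyond the scatter), so the change does not depend on removing the net charge of the groups in compound 2 and compound 3.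

Going by these compounds, the true size of these steps stays open, since each rests on a limit, and so does the question of whether the five-membered ring or its second ring nitrogen goes with the loss. A phenyl, thiophen-2-yl or pyrazol-1-yl group on the same aromatic carbon would help separate those two features.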